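The compounds below may be only part of what the source reports. "The series", "measured", "known", "first", "only" and "open" are said of these compounds alone.

Measured so far:
compound 1 `COc1ccc(C(=O)Nc2ccccc2C)cc1OC1CCCC1` — 300 nM
compound 2 `COc1ccc(C(=O)Nc2ccccc2Cl)cc1OC(=O)C1CCCC1` — > 1000000 nM

Working notes on the series. In an assay on isolated protein for inhibition of phosphodiesterase 4A (Sus scrofa) (a higher number here means a weaker inhibitor, a lower number a stronger inhibitor), compound 1 gives 300 nM. Among the compounds with values here, this is the only number in the set: the second value is not a number but a limit of the assay. Compound 2 `COc1ccc(C(=O)Nc2ccccc2Cl)cc1OC(=O)C1CCCC1` returns > 1000000 nM in this assay, a limit only. On the numbers shown, compound 1 therefore stands alone; there is the limit of > 1000000 nM in this assay, at which 1 of the 2 values shown sits, and nothing in between, so no measured step between two compounds that differ in one place is available.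

The next compound, compound 3 `COc1ccc(C(=O)NC2(C)C=C(C)ON2)cc1OC1CCCC1`, has not been measured. It differs from compound 1 as follows: a group of 7 heavy atoms (5 carbon, 1 nitrogen, 1 oxygen; one five-membered non-aromatic ring with 2 hetero atoms) in place of a group of 7 heavy atoms (7 carbon; one six-membered aromatic ring of carbon only), on an amide-type nitrogen. The shared core of compound 1 is kept. Within the data shown here, no measured step covers a change of this kind, so the size is a judgement on the change alone, not on data. The step of a 10-fold higher number from compound 1 to compound 3 (1.00 log units; beyond the scatter) is expected to be a weakening beyond the usual scatter. Compound 3 is expected to give 3000 nM in this assay, with a likely range from 500 nM to 20000 nM.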

Compound 3, half-maximal inhibitory concentration: 450 nM
Beside the measured number, compound 3's estimate is 6.7-fold (0.82 log units) above it, outside the stated range (below it).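

In this assay, exchanging the group on the amide-type nitrogen gives a 1.5-fold higher number from compound 1 to compound 3 (0.18 log units; within the scatter). This first readable step in the series shows that, with the shared core kept, the 2-methylphenyl group and its six-membered aromatic ring of carbon only can give way to a five-membered non-aromatic ring with 2 hetero atoms without a difference that can be told from the scatter, so an aromatic ring of carbon only is not needed at this place for a value of this order. No measurement shown bears on the reason for this result.

The compounds shown leave open whether this tolerance extends to other groups on the amide-type nitrogen, such as a pyridine ring, an unsubstituted phenyl, a short ethyl chain or a group carrying a carboxylic acid. They also leave open which parts of the five-membered ring matter, since its methyl groups, its double bond and its ring oxygen change together in this single step and cannot be separated.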